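Swapping a methyl for an oxolane ring on a quinazoline series

A few compounds are considered here, and "the series" means these few. Any claim that something is new, unique, unknown or untested is made for them only; others in the source may bear on it.

Compound 1 `C/C=C/C(=O)Nc1cc2c(N3CCCc4ccccc43)ncnc2cc1OC` and compound 2 `C/C=C/C(=O)Nc1cc2c(N3CCCc4ccccc43)ncnc2cc1O[C@@H]1CCOC1` share one core and differ by oxolan-3-yl in place of methyl on an oxygen on an aromatic ring. In a functional assay on A549 cells (Homo sapiens) for antiproliferative activity, read by MTT assay, with a stated time of 72 h (on this read-out lower numbers stand for stronger inhibition and higher numbers for weaker inhibition), compound 1 gives 8190 nM, and compound 2 gives 10800 nM, so the change made a 1.3-fold higher number from compound 1 to compound 2 (0.12 log units; within the scatter). Compound 3 `COc1cc2ncnc(N3CCc4ccccc43)c2cc1NC(=O)/C=C/CN(C)C` is built on a different core; how the two cores differ is not broken down here. In this assay compound 3 gives 2040 nM, the lowest of the three numbers. Compound 4 `CN(C)C/C=C/C(=O)Nc1cc2c(N3CCc4ccccc43)ncnc2cc1O[C@@H]1CCOC1` is not yet measured and differs from compound 3 by oxolan-3-yl in place of methyl on an oxygen on an aromatic ring, the same change seen between compound 1 and compound 2. Because the earlier step was a 1.3-fold higher number from compound 1 to compound 2 (0.12 log units; within the scatter), a similar small step, a 1.3-fold higher number from compound 3 to compound 4 (0.11 log units; within the scatter), is expected here, resting on that single precedent. Compound 4 is therefore estimated at 2600 nM, likely between 1000 nM and 6500 nM.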

Compound 4, half-maximal inhibitory concentration: 1090 nM
Compound 4: middle estimate off by 2.4-fold (0.38 log units), on the high side; low and high end bracket the measured number.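

On the second core, the swap from methoxy to (oxolan-3-yl)oxy gives a 1.9-fold lower number from compound 3 to compound 4 (0.27 log units; within the scatter) in this assay. Set beside the step on the first core, this shows that the swap carries across these two cores with no difference that can be told from the scatter: the same change on two cores in this assay, a 1.3-fold higher number (0.12 log units; within the scatter) from compound 1 to compound 2 and a 1.9-fold lower number (0.27 log units; within the scatter) from compound 3 to compound 4, 2.5-fold (0.39 log units) apart, within the scatter of two such steps. Within the data shown here, that rests on only two pairs in one cell assay, so it does not show that the swap would behave the same way on any other core, or whether either small step has a real direction.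

The compounds shown leave open what a different group on that oxygen would do, such as ethyl or a longer chain ending in an amine. They also leave open whether the opposite stereocentre in the oxolan-3-yl group would give a similar number.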